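From Azido to Chloro on the Chain

The compounds below may be only part of what the source reports. "The series", "measured", "known", "first", "only" and "open" are said of these compounds alone.

In a functional assay on SW480 cells (Homo sapiens) for antiproliferative activity, read by MTT assay, with a stated time of 48 h (on this read-out higher numbers stand for weaker inhibition and lower numbers for stronger inhibition), compound 1 (`CCCCCCCCCC(CCO)n1cnc2c(Cl)nc(F)nc21`) gives 12500 nM and compound 2 (`CCCCCCCCCC(CCN=[N+]=[N-])n1cnc2c(Cl)ncnc21`) gives 1200 nM on the same scale. Compound 3 (`CCCCCCCCC[C@H](CCN=[N+]=[N-])n1cnc2c(Cl)ncnc21`) stands at 1220 nM there, level with compound 2 and well under compound 1. Within the data shown here, the one measured step, which is a 1.0-fold higher number from compound 2 to compound 3 (0.01 log units; within the scatter) and concerns only the fact that one of compounds 2 and 3 is drawn with a defined configuration and the other without, at the place where they differ as its difference, does not bear on the group exchanged next. Among the measured compounds shown here, compound 4 (`CCCCCCCCC[C@H](CCCl)n1cnc2c(Cl)ncnc21`) differs from compound 3 by chloro in place of azido on a saturated chain carbon, three bonds along the chain from an aromatic nitrogen and no measured pair shows that exchange. With compound 3 at 1220 nM as the only anchor, no change beyond the scatter is expected in this assay and the expected step is a 1.2-fold higher number from compound 3 to compound 4 (0.09 log units; within the scatter) with a slight lean toward a higher number. The estimated value for compound 4 is 1500 nM (expected range 500 nM to 4500 nM).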

Compound 4, half-maximal inhibitory concentration: 3180 nM
Compound 4: the middle estimate sits 2.1-fold (0.33 log units) below what was measured; the range from low to high includes it.
By their numbers in this assay, from the lowest: compounds 2 and 3 (each within the scatter of the next); then compound 4; then compound 1.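

In this assay, the group on this saturated chain carbon, three bonds along the chain from an aromatic nitrogen, matters to the read-out: a 2.6-fold higher number from compound 3 to compound 4 (0.42 log units; beyond the scatter). The earlier pair differed only in drawn configuration, so it could not show that exchanging azido for chloro at this place moves the number beyond the scatter. Nothing shown accounts for the size or direction of this step.

The compounds shown leave open how an amine or a carboxylic acid at this place would read. They also leave open whether the same exchange gives a similar step on a longer chain.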